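A few compounds are considered here, and "the series" means these few. Any claim that something is new, unique, unknown or untested is made for them only; others in the source may bear on it.

Compound 1 `COC(=O)c1nc(C)n(-c2ccc(OC)cc2)n1`, in a functional assay on Jurkat cells (Homo sapiens) for inhibition, read by MTT assay, with a stated time of 72 h (on this read-out lower numbers stand for stronger inhibition of growth and higher numbers for weaker inhibition of growth), gives only a limit of the assay, > 100000 nM.
Compound 2 `CCCCc1nc(C(=O)OC)nn1-c1ccc(F)cc1`, in this assay, gives only a limit of the assay, > 100000 nM.

Compound 2 stands where every value shown stands: at the limit of > 100000 nM in this assay, at which 2 of the 2 values shown sit. Going by the values given here, no two measured compounds differ in one place, so no step has been measured. Compound 3 `COC(=O)c1nc(-c2ccccc2)n(-c2ccc(F)cc2)n1` differs from compound 2 by phenyl in place of butyl on an aromatic carbon. With both known values sitting at the limit, no direction for this move in this assay can be read from them. Compound 3 is therefore expected to stay near the same limit, with a wide range, giving an estimate of 100000 nM (from 20000 nM to 300000 nM), which means an expected step of a number no higher from compound 2 to compound 3 (the limit leaves the size open).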

Compound 3, concentration for 50% growth inhibition: 10000 nM
Compound 3: middle estimate off by 10-fold (1.00 log units), on the high side; the whole stated range lies above it.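

In this assay, phenyl in place of butyl on the aromatic carbon between two ring nitrogen atoms gives an at least 10-fold lower number from compound 2 to compound 3 (1.00 log units; beyond the scatter). Compound 3 is the only compound shown with a value that is not a limit, so the group at this position can change the read-out. The full size of the step stays open because compound 2 gives only a limit: the limit of > 100000 nM in this assay, at which 2 of the 3 values shown sit.

Going by these compounds, whether a benzyl or cyclohexyl group at this position would give a lower or higher number remains open. So does whether a ring is needed here at all, since a longer chain could also be tested.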